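This account rests on a few compounds, and the source may have more. Where it says the series, first, only, none or still open, it means among the compounds named here.

Working notes on the series in a functional assay on IGROV-1 cells (Homo sapiens) for inhibition, read by sulforhodamine B assay, with a stated time of 48 h, tested at 10 uM; on this read-out higher numbers stand for a weaker effect at the one concentration tested and lower numbers for a stronger effect.

Compound 2 `O=C(Nc1cccc(-n2cc(-c3ccncc3)c(-c3cc(O)cc(Cl)c3)n2)c1)Nc1ccc(Cl)c(Cl)c1` gives 26% in this assay. For the measured compounds named here, its only neighbour on the numbers is compound 1 `O=C(Nc1cccc(-n2cc(-c3ccncc3)c(-c3cc(O)cc(Cl)c3)n2)c1)Nc1ccc(Cl)c(C(F)(F)F)c1`, which in this assay gives 30.6%; the step of a number 4.6 percentage points lower from compound 1 to compound 2 (within the scatter) is within the scatter, so the two compounds sit together and neither can be set apart from the other on this read-out. That step swaps one group for another on the outer aromatic ring of the urea and says nothing about the hydroxy-bearing ring.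

Compound 3 `COc1cc(Cl)cc(-c2nn(-c3cccc(NC(=O)Nc4ccc(Cl)c(Cl)c4)c3)cc2-c2ccncc2)c1` differs from compound 2 by methyl in place of hydrogen on an oxygen on an aromatic ring. Going by the values given here, no measured step touches this position: the single step known, from compound 1 to compound 2, lies elsewhere in the molecule and was itself within the scatter. With nothing to point either way, the expectation is a step of a number 4 percentage points higher from compound 2 to compound 3 (within the scatter) in this assay, that is, no change beyond the scatter. The estimate for compound 3 in this assay is therefore 30%, with a range from 12% to 55%.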

Compound 3, a percentage reported as activity, at one concentration (the size of the read-out at that concentration, not a potency): 36.7%
Estimate against measurement, compound 3: 6.7 percentage points below, and the stated range covers the measured number.
By their numbers in this assay, from the lowest: compounds 2, 1 and 3 (each within the scatter of the next, the first and the last beyond it).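

Going from hydroxy to methoxy on the 3-chloro-5-hydroxyphenyl ring gives the first step at this position in this assay, and it reads a number 10.7 percentage points higher from compound 2 to compound 3 (beyond the scatter). On this read-out, the higher number means a weaker effect at the one concentration tested, so methyl in place of hydrogen on this oxygen costs a modest amount of effect. This position therefore responds to change, unlike the outer aromatic ring of the urea, where the only step shown, a number 4.6 percentage points lower from compound 1 to compound 2 (within the scatter), could not separate the two compounds. No measurement shown offers an explanation for the step at the oxygen.

The compounds shown leave open whether the free hydroxy itself matters or whether any group on this oxygen would give a similar step, a question that a longer chain such as ethoxy, or an amine in place of the hydroxy, would help to settle. Also open, as far as these compounds go, is whether the same change gives a step of similar size when trifluoromethyl stands on the outer ring, as it does in compound 1.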